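The source may report more compounds than this note shows. Statements on the series, on what has been measured and on what is new or still open speak of the compounds shown alone.

Measured compounds:
Compound 1 `Cc1cnc(Nc2ccc(S(C)(=O)=O)cc2)nc1Nc1nc2ccc(Cl)cc2s1`: 4180 nM
Compound 2 `NS(=O)(=O)c1ccc(Nc2ncc(F)c(Nc3nc4ccc(Cl)cc4s3)n2)cc1`: 8770 nM
Compound 3 `CS(=O)(=O)c1ccc(Nc2ncc(F)c(Nc3nc4ccc(Cl)cc4s3)n2)cc1`: > 50000 nM

These three compounds share one core and were tested in a functional assay on HeLa cells (Homo sapiens) for antiproliferative activity, read by MTT assay, with a stated time of 48 h; on this read-out lower numbers stand for stronger inhibition and higher numbers for weaker inhibition. Compound 1 gives 4180 nM and compound 2 gives 8770 nM. Compound 3 is a different case: its value of > 50000 nM is not a number but a limit of this assay, so compound 3 is known only to sit at or past (the limit of > 50000 nM in this assay, at which 1 of the 3 values shown sits). Of the three compounds shown, compound 3 is therefore the one whose position on the scale is least defined.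

Two measured steps lead to compound 3. The change of methyl to fluoro gives an at least 11-fold higher number from compound 1 to compound 3 (1.07 log units; beyond the scatter), and the change of amino to methyl on the sulfonyl sulfur gives an at least 5.7-fold higher number from compound 2 to compound 3 (0.75 log units; beyond the scatter). Both moved toward weaker inhibition.

Compound 4 `COc1ccc2nc(Nc3nc(Nc4ccc(S(C)(=O)=O)cc4)ncc3F)sc2c1` differs from compound 3 in one place: methoxy in place of chloro on an aromatic carbon. Going by the values given here, no measured step touches this position, so neither of the steps above speaks to it directly. Among the compounds with values here, the only anchor is that compound 3 itself sits at a limit. With no guidance from the data, the expected step of an at least 1.2-fold lower number from compound 3 to compound 4 (0.09 log units; that floor lies within the scatter) is small. For compound 4 the estimated value in this assay is 40000 nM, with a range from 8000 nM to 200000 nM.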

Compound 4, half-maximal inhibitory concentration: 25400 nM
Compound 4: middle estimate off by 1.6-fold (0.20 log units), on the high side; the range from low to high includes it.
By their numbers in this assay, from the lowest: compound 1; then compound 2; then compound 4. At a limit, above all of these: compound 3.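

In this assay, the position on the six-membered aromatic ring of carbon only now has its first comparison: methoxy in place of chloro gives an at least 1.9-fold lower number from compound 3 to compound 4 (0.29 log units; that floor lies within the scatter). With methoxy at this position, compound 4 gives 25400 nM, an actual number on the scale, so this swap yields a reading that can serve as a reference for later comparisons. The true gap may be larger than the printed floor, and whether it goes beyond the usual scatter cannot be settled, because compound 3 stands at a limit of the assay: the limit of > 50000 nM in this assay, at which 1 of the 4 values shown sits.

The compounds shown leave open how other groups at this position would read, such as an amine, a carboxylic acid or the longer ethoxy chain. They also leave open what methoxy in place of chloro would do in compound 1 or compound 2, where both ends of the step could be real numbers and its size could therefore be read directly.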